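Urea series, aorta inhibition: phenyl to pyridinyl step

The source may hold more compounds than are shown below. What is called first, only, known or untested is meant among the compounds shown, and "the series" means these compounds.

compound 1 `CC1(C)Oc2ccc(C#N)cc2[C@@H](/N=C(\NC#N)Nc2ccccc2)[C@@H]1O`: 1400000 nM
compound 2 `CC(C)(C)c1ccc(C#N)cc1NC(=O)Nc1ccccc1`: 1700000 nM

In a functional assay (aorta) for inhibition, with Rattus norvegicus as the target (a lower number here means a stronger inhibitor, a higher number a weaker inhibitor), compound 1 gives 1400000 nM and compound 2 gives 1700000 nM. The two numbers lie within the usual scatter of each other, so compound 2 is not set apart from compound 1 by these data. Compound 3 `CC(C)(C)c1ccc(C#N)cc1NC(=O)Nc1cccnc1` carries pyridin-3-yl in place of phenyl on an amide-type nitrogen. Among the compounds with values here, no step between measured compounds bears on this change, so no step beyond the scatter is expected in this assay. Compound 3 is therefore estimated at 1700000 nM, with a range of 600000 nM to 5000000 nM. The step from compound 2 to compound 3 implied by this estimate is no change at the digits printed from compound 2 to compound 3 (within the scatter).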

Compound 3, half-maximal inhibitory concentration: 25700000 nM
Compound 3: middle estimate off by 15-fold (1.18 log units), on the low side; the whole stated range lies below it.
By their numbers in this assay, from the lowest: compounds 1 and 2 (each within the scatter of the next); then compound 3.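

In this assay pyridin-3-yl in place of phenyl on an amide-type nitrogen gives a 15-fold higher number from compound 2 to compound 3 (1.18 log units; beyond the scatter), so this position responds strongly to one ring carbon becoming nitrogen, in the direction of weaker inhibition. Compound 1 and compound 2 differ in more than one place and gave no reading of this position. No measurement bears on why the number rises.

As far as these compounds go, whether a cyclohexyl ring or a short alkyl chain at this nitrogen would stay close to compound 2 or move like compound 3 remains open. From the compounds shown here alone, whether the same step holds on the core of compound 1 also remains open.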